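The compounds below may be only part of what the source reports. "The series", "measured", "known", "first", "only" and "open" are said of these compounds alone.

Measured so far in a toxicity assay on CCRF-CEM cells (Homo sapiens) for cytotoxicity; on this read-out lower numbers stand for higher toxicity in this test and higher numbers for lower toxicity in this test:
- compound 1 `CCc1cccc2c1nc(-c1c(F)cccc1F)n2Cc1c(F)cccc1F`: 26.1 uM
- compound 2 `Oc1cccc2c1nc(-c1c(F)cccc1F)n2Cc1c(F)cccc1F`: > 100 uM (a limit)
- compound 3 `Nc1cccc2c1nc(-c1c(F)cccc1F)n2Cc1c(F)cccc1F`: 26.3 uM

The three compounds share one core and differ in a single group on an aromatic carbon. Compound 2, the hydroxy member, has no numerical reading, and its > 100 uM is a limit of the assay. Its place in the series is therefore known only through (the limit of > 100 uM in this assay, at which 1 of the 3 values shown sits).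

The next compound is compound 4 `CC(=O)N(C)c1cccc2c1nc(-c1c(F)cccc1F)n2Cc1c(F)cccc1F`, which has acetyl(methyl)amino in place of hydroxy on an aromatic carbon. The group sits ortho to a fused ring and meta to a fused ring.

Two measured steps lead away from the hydroxy compound or towards it. One is an at least 3.8-fold higher number from compound 1 to compound 2 (0.58 log units; beyond the scatter), and the other is an at least 3.8-fold lower number from compound 2 to compound 3 (0.58 log units; beyond the scatter). Both lie beyond the scatter. Ethyl and amino themselves do not separate, with a 1.0-fold higher number from compound 1 to compound 3 (0.00 log units; within the scatter) falling within the scatter.

Neither of those steps involves an acylated group, so the transfer to compound 4 is uncertain. Even so, a modest step to a lower number is expected, which would place compound 4 near compound 1 and compound 3 or somewhat higher. The expected step is an at least 2.2-fold lower number from compound 2 to compound 4 (0.34 log units; beyond the scatter). For compound 4 the estimated value is 45 uM, with an expected range of 18 uM to 100 uM.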

Compound 4, half-maximal toxic concentration: > 100 uM
Compound 4: no number, only a limit (the forecaster's own chance of this, stated with the estimate: 35%); at least 2.2-fold (0.34 log units) between middle value and limit.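

In this assay compound 4 gives > 100 uM, which is a limit of the assay and not a number. At this aromatic carbon, ortho to a fused ring and meta to a fused ring, acetyl(methyl)amino now joins hydroxy on the high side of the series, with an at least 3.8-fold higher number from compound 3 to compound 4 (0.58 log units; beyond the scatter) and an at least 3.8-fold higher number from compound 1 to compound 4 (0.58 log units; beyond the scatter), so a nitrogen attached at this carbon does not by itself go with the lower number that the amino member shows. Compound 2 and compound 4 both rest on limits, so the step between them cannot be read and the order of hydroxy and acetyl(methyl)amino stays unknown: the limit of > 100 uM in this assay, at which 2 of the 4 values shown sit.

On these data alone, what remains open is which part of the acetyl(methyl)amino group goes with the step away from compound 3, and a methylamino or an acetylamino group on the same carbon would separate the methyl from the acetyl. As far as these compounds go, it is also open whether a methoxy group on this carbon would read with hydroxy and acetyl(methyl)amino or with ethyl and amino, and how far compound 2 and compound 4 actually lie from the other two compounds.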